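The source may hold more compounds than are shown below. What is called first, only, known or untested is meant among the compounds shown, and "the series" means these compounds.

Compound 1 `Fc1cccc(-c2nc(Nc3ccccc3)c3ccccc3n2)c1` in a functional assay on HL-60 cells (Homo sapiens) for cytotoxicity, read by MTT assay, with a stated time of 48 h (on this read-out higher numbers stand for weaker inhibition and lower numbers for stronger inhibition), gives > 50000 nM, a limit of the assay.
Compound 2 `COc1ccccc1Nc1nc(-c2cccc(F)c2)nc2ccc(F)cc12` in this assay gives > 50000 nM, again a limit.
Compound 3 `Fc1ccc(Nc2nc(-c3cccc(F)c3)nc3ccc(F)cc23)cc1` in this assay gives > 50000 nM, also a limit.

Compound 3 therefore stands at the limit of the assay, where every value shown in the series sits (the limit of > 50000 nM in this assay, at which 3 of the 3 values shown sit). Compound 4 `Fc1cccc(-c2nc(Nc3ccccc3F)c3cc(F)ccc3n2)c1` differs from compound 3 by 2-fluorophenyl in place of 4-fluorophenyl on a nitrogen on an aromatic ring. For the measured compounds named here, the one measured step, a step that the two limits leave unreadable from compound 2 to compound 3, runs between two limits and gives no readable size, so no measured step bears on the change to compound 4 in this assay. The step is expected to be a step that the limit leaves unreadable from compound 3 to compound 4, that is, no readable change. Compound 4 is estimated at 60000 nM, with a range from 20000 nM to 200000 nM, most probably reported as a limit again.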

Compound 4, half-maximal inhibitory concentration: > 50000 nM
Compound 4: only a limit was reported (the forecaster's own chance of this, stated with the estimate: 85%); the middle value does not contradict the limit.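

Compound 4 gives > 50000 nM in this assay, a limit of the assay. Its steps from compound 2 and compound 3 run between limits and cannot be read. The compounds shown leave open whether any change on the shared core gives a readable value: the limit of > 50000 nM in this assay, at which 4 of the 4 values shown sit.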